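Acyl thiourea series: benzothiophene carbonyl in place of furan carbonyl

A few compounds are considered here, and "the series" means these few. Any claim that something is new, unique, unknown or untested is made for them only; others in the source may bear on it.

Measured so far in an ADME assay on Huh-7 cells (Homo sapiens) for cytotoxicity; on this read-out higher numbers stand for lower toxicity in this test and lower numbers for higher toxicity in this test: compound 1 `CN(C)c1ccc(C(=O)NC(=S)N2CCc3c(OCCCCCOc4ccc(Cl)cc4)cccc32)cc1` gives > 50000 nM, which is a limit of the assay. Compound 2 `O=C(NC(=S)N1CCc2c(OCCCCCOc3ccc(Cl)cc3)cccc21)c1ccco1` gives 4620 nM.

Compound 2 thus holds the only number shown in this assay; the other value is a limit. Among the compounds with values here, the one measured step at the carbonyl carbon, an at least 10-fold lower number from compound 1 to compound 2 (1.03 log units; beyond the scatter), rests on (the limit of > 50000 nM in this assay, at which 1 of the 2 values shown sits), so its true size is open upward.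

Compound 3 `O=C(NC(=S)N1CCc2c(OCCCCCOc3ccc(Cl)cc3)cccc21)c1cc2ccccc2s1` differs from compound 2 by 1-benzothiophen-2-yl in place of furan-2-yl on a carbonyl carbon. Within the data shown here, the single measured step at this position shows that the aryl group on the carbonyl carbon can move the read-out a great deal, but with only one such step, ending at a limit, neither direction nor size for a second aryl swap can be read off. Among the measured compounds shown here, the expectation is therefore a modest step, if any, with wide uncertainty, leaning toward a lower number since the sole known number sits below the limit. For compound 3 the expected value is 4000 nM, with a range from 1000 nM to 25000 nM. This expectation corresponds to a 1.2-fold lower number from compound 2 to compound 3 (0.06 log units; within the scatter).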

Compound 3, half-maximal cytotoxic concentration: > 50000 nM
Compound 3 was reported as a limit (the forecaster's own chance of this, stated with the estimate: 20%); middle value at least 12-fold (1.09 log units) from the limit.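

In this assay, 1-benzothiophen-2-yl in place of furan-2-yl on the carbonyl carbon gives an at least 10-fold higher number from compound 2 to compound 3 (1.03 log units; beyond the scatter). Compound 3 gives > 50000 nM, which is a limit of the assay, and compound 1 is also a limit, so of the three groups on the carbonyl carbon only furan-2-yl gives a number. The step between compound 1 and compound 3 cannot be read, and the true size of the step to compound 3 stays open upward: the limit of > 50000 nM in this assay, at which 2 of the 3 values shown sit.

As far as these compounds go, whether the number in compound 2 goes with the single five-membered ring or with its oxygen stays open, and thiophen-2-yl on the same carbonyl carbon would separate the two. From the compounds shown here alone, whether a non-aromatic group such as cyclopropyl there also gives a number below the limit is equally open.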